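The source may hold more compounds than are shown below. What is called first, only, known or untested is meant among the compounds shown, and "the series" means these compounds.

Measured in a functional assay on MDA-MB-231 cells (Homo sapiens) for inhibition, read by MTT assay, with a stated time of 72 h; a lower number here means a stronger inhibitor, a higher number a weaker inhibitor:
- compound 1 `COC(=O)c1ccc(-n2cc(CCCNC(=O)c3ccc(C)cc3)nn2)cc1`: > 100000 nM (a limit, not a number)
- compound 2 `COC(=O)c1ccc(-n2cc(CCCNC(=O)Nc3ccc(C)cc3)nn2)cc1`: 11600 nM
- compound 3 `COC(=O)c1ccc(-n2cc(CCCn3nnc(-c4ccc(C)cc4)n3)nn2)cc1`: 36500 nM

Compound 1 stands at the limit of > 100000 nM in this assay, at which 1 of the 3 values shown sits, and this is only a limit. Compound 4 `COC(=O)c1ccc(-n2cc(CCCNc3ccc(C)cc3)nn2)cc1` has not yet been measured. It differs from compound 1 by 4-methylphenyl in place of (4-methylphenyl)carbonyl on an amine nitrogen, with 4-methylphenyl in place of (4-methylphenyl)carbonyl on an amine nitrogen. Going by the values given here, only one measured step bears on this, and only in part: an at least 8.6-fold lower number from compound 1 to compound 2 (0.93 log units; beyond the scatter), beyond the scatter. In that step the carbonyl stays, whereas here it leaves. A step of similar size towards a lower number in this assay therefore seems likely, though the uncertainty is wide. The expected change is an at least 5.0-fold lower number from compound 1 to compound 4 (0.69 log units; beyond the scatter). Compound 4 is estimated at 20000 nM, with an expected range of 5000 nM to 80000 nM.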

Compound 4, half-maximal inhibitory concentration: 33000 nM
For compound 4 the middle estimate is 1.7-fold (0.22 log units) below the measured one, and the stated range covers the measured number.
By their numbers in this assay, from the lowest: compound 2; then compounds 4 and 3 (each within the scatter of the next). At a limit, above all of these: compound 1.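

Taking the carbonyl away altogether, so that 4-methylphenyl sits directly on the amine nitrogen, gives an at least 3.0-fold lower number from compound 1 to compound 4 (0.48 log units; beyond the scatter) in this assay. The earlier step kept the carbonyl, so only this one shows that a measurable number in this assay does not depend on a carbonyl at this position. The step's size is only a bound, since compound 1 is held at a limit: the limit of > 100000 nM in this assay, at which 1 of the 4 values shown sits.

On these data alone, what a sulfonyl or a benzyl group on this amine nitrogen would give remains open. Also open, as far as these compounds go, is whether the nitrogen itself is needed, which an ether oxygen in its place would test.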